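The source may report more compounds than this note shows. Statements on the series, on what has been measured and on what is new or still open speak of the compounds shown alone.

Compound 1 `CCOC(=O)c1c(-c2cc3cc(OC)ccc3oc2=O)nn(-c2ccccc2)c1C(=O)OCC` gives 35000 nM in a functional assay on A549 cells (Homo sapiens) for cytotoxicity, read by MTT assay, with a stated time of 48 h; a higher number here means a weaker inhibitor, a lower number a stronger inhibitor. Compound 2 `CCOC(=O)c1c(-c2cc3cc(OC)ccc3oc2=O)nn(-c2cccc(C)c2)c1C(=O)OCC` gives 102000 nM. Compound 3 `CCOC(=O)c1c(-c2cc3ccc(OC)cc3oc2=O)nn(-c2ccccc2)c1C(=O)OCC` gives 132000 nM.

Compound 1 and compound 2 share a core and differ by methyl in place of hydrogen on an aromatic carbon. That change gives a 2.9-fold higher number from compound 1 to compound 2 (0.46 log units; beyond the scatter). Compound 3 carries a core of the same atoms joined differently from those of compound 1; the difference between the two cores is not broken down here. Compound 3 stands at the highest number of the three, within the scatter of compound 2 and beyond it from compound 1.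

Compound 4 `CCOC(=O)c1c(-c2cc3ccc(OC)cc3oc2=O)nn(-c2cccc(C)c2)c1C(=O)OCC` is not yet measured. It differs from compound 3 by methyl in place of hydrogen on an aromatic carbon, the same change that was made from compound 1 to compound 2. Within the data shown here, for compound 4 the step from compound 3 is expected to be a 2.4-fold higher number from compound 3 to compound 4 (0.38 log units; beyond the scatter), on the grounds that the matching change on the other core gave a 2.9-fold higher number from compound 1 to compound 2 (0.46 log units; beyond the scatter), while only one such step exists to lean on. Compound 4 is therefore expected to give 320000 nM in this assay, estimated between 130000 nM and 800000 nM.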

Compound 4, half-maximal inhibitory concentration: 171000 nM
Compound 4: middle estimate off by 1.9-fold (0.27 log units), on the high side, within the range that was stated.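

On the core of compound 3, going from phenyl to 3-methylphenyl gives a 1.3-fold higher number from compound 3 to compound 4 (0.11 log units; within the scatter) in this assay and so leaves no readable change, whereas the same change on the core of compound 1 gave a 2.9-fold higher number from compound 1 to compound 2 (0.46 log units; beyond the scatter) as a modest step. Among these compounds, only the step on the core of compound 1 lies beyond the scatter, yet the two steps cannot be told apart: the same change on two cores in this assay, a 2.9-fold higher number (0.46 log units; beyond the scatter) from compound 1 to compound 2 and a 1.3-fold higher number (0.11 log units; within the scatter) from compound 3 to compound 4, 2.2-fold (0.35 log units) apart, within the scatter of two such steps. The data are therefore compatible with the change carrying over from one core to the other, but they do not establish that it does, since they rest on a single pair of steps, one of them too small to read.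

The compounds shown leave open what a chlorine, an amine or a carboxylic acid in place of the methyl would do on either core. Also open, going by these compounds, is whether replacing either ethyl ester with a carboxylic acid or an amide would alter the number in this assay on these cores.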